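Aryl urea variation on the shared core: toward compound 3

This account rests on a few compounds, and the source may have more. Where it says the series, first, only, none or still open, it means among the compounds named here.

Measured so far:
- compound 1 `Cc1ccc(NC(=O)Nc2nnc(Sc3ncnc4scc(-c5ccncc5)c34)s2)cc1Cl`; in a functional assay on HUVEC cells (Homo sapiens) for antiproliferative activity, read by MTT assay, with a stated time of 48 h (on this read-out higher numbers stand for weaker inhibition and lower numbers for stronger inhibition), compound 1 gives 23200 nM
- compound 2 `O=C(Nc1ccc(F)cc1)Nc1nnc(Sc2ncnc3scc(-c4ccncc4)c23)s1`; in this assay compound 2 gives 28300 nM

Within the data shown here, compound 2 carries the higher of the two numbers so far in this assay, but the only step leading to it, a 1.2-fold higher number from compound 1 to compound 2 (0.09 log units; within the scatter), sits within the scatter, so no order between compound 1 and compound 2 is claimed.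

Compound 3 `O=C(Nc1ccc(Cl)c(Cl)c1)Nc1nnc(Sc2ncnc3scc(-c4ccncc4)c23)s1` awaits measurement. Relative to compound 2 the change is 3,4-dichlorophenyl in place of 4-fluorophenyl on an amide-type nitrogen. Among the measured compounds shown here, the single measured step that touches this position is a 1.2-fold higher number from compound 1 to compound 2 (0.09 log units; within the scatter): one substituted phenyl replaced another on the same amide-type nitrogen and the number did not leave the scatter. The 3,4-dichlorophenyl entering in compound 3 carries chlorine, as does the 3-chloro-4-methylphenyl of compound 1, whereas the 4-fluorophenyl of compound 2 carries fluorine; on the two numbers available, this distinction produced nothing beyond the scatter.

The step expected from compound 2 to compound 3 in this assay is therefore a 1.3-fold lower number from compound 2 to compound 3 (0.11 log units; within the scatter), with no direction asserted beyond the scatter. Compound 3 is estimated at 22000 nM, in the range 9000 nM to 55000 nM.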

Compound 3, half-maximal inhibitory concentration: 7800 nM
Estimate against measurement, compound 3: 2.8-fold (0.45 log units) above, and the stated range ends above it.
By their numbers in this assay, from the lowest: compound 3; then compounds 1 and 2 (each within the scatter of the next).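

In this assay the group on the amide-type nitrogen now proves able to move the number, since 3,4-dichlorophenyl in place of 4-fluorophenyl gives a 3.6-fold lower number from compound 2 to compound 3 (0.56 log units; beyond the scatter) and so goes beyond the scatter, which the earlier exchange of one substituted phenyl for another did not. Chloro in place of methyl on an aromatic carbon gives a 3.0-fold lower number from compound 1 to compound 3 (0.47 log units; beyond the scatter) and is also beyond the scatter, so the presence of one chlorine on the phenyl ring does not by itself set the number: compound 1 also carries chlorine, yet it stays within the scatter of compound 2, while compound 3 has the lowest number of the three. Among these compounds, nothing measured so far accounts for the difference between these aryl groups.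

Still open, as far as these compounds go, is whether the lower number depends on both chlorines of the 3,4-dichlorophenyl group, a question that a monochlorophenyl, a bromophenyl or an unsubstituted phenyl on the same nitrogen would address. Equally open, from the compounds shown here alone, is how the series responds to a trifluoromethylphenyl, to a cyclohexyl group in place of the aromatic ring, or to a phenyl ring bearing an amine or a carboxylic acid.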